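The source may report more compounds than this note shows. Statements on the series, on what has been measured and on what is new or still open speak of the compounds shown alone.

Of the compounds shown here, three sharing one core have been tested in a functional assay on KB cells (Homo sapiens) for antiproliferative activity, read by sulforhodamine B assay, with a stated time of 3 days; a higher number here means that more compound is needed for the effect, a lower number that less compound is needed. Compound 1, `CCC1=C(O)c2c(oc(-c3ccc(CC(C)C)cc3)cc2=O)C(CC)(CC)C1=O`, gives 29.3 uM. Compound 2, `CCC1=C(O)c2c(oc(-c3cccc(C(F)(F)F)c3)cc2=O)C(CC)(CC)C1=O`, gives 35.7 uM, and these two numbers lie within the usual scatter of each other. Compound 3, `CCC1=C(O)c2c(oc(-c3cccc(F)c3)cc2=O)C(CC)(CC)C1=O`, reaches only a limit of the assay, > 56.2 uM, so for compound 3 the data give a bound and not a number. That bound is the one recorded in the limit of > 56.2 uM in this assay, at which 1 of the 3 values shown sits. Going by the values given here, the one measured step that reaches compound 3 is an at least 1.5-fold higher number from compound 2 to compound 3 (0.19 log units; that floor lies within the scatter); it gives only a floor, and that floor lies within the scatter.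

Compound 4, `CCC1=C(O)c2c(oc(-c3cc(C)cc(C)c3)cc2=O)C(CC)(CC)C1=O`, has not yet been measured. The change from compound 3 is 3,5-dimethylphenyl in place of 3-fluorophenyl on an aromatic carbon. Among the compounds with values here, no measured step covers this kind of change, so the expectation rests on the spread of the three numbers above. Compound 1 and compound 2, carrying other substituted phenyl groups, both give numbers rather than limits, which suggests that compound 4 is more likely to return a number than another limit. Compound 4 is therefore expected to give about 35 uM, with a range from 15 uM to 80 uM. This estimate means a step of an at least 1.6-fold lower number from compound 3 to compound 4 (0.20 log units; that floor lies within the scatter), though a further limit cannot be excluded.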

Compound 4, concentration for half-maximal effect: 45.5 uM
Estimate against measurement, compound 4: 1.3-fold (0.11 log units) below, and the stated range covers the measured number.
By their numbers in this assay, from the lowest: compounds 1, 2 and 4 (each within the scatter of the next). At a limit, above all of these: compound 3.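

In this assay compound 4 gives 45.5 uM, so 3,5-dimethylphenyl on this aromatic carbon, next to the ring oxygen, yields a real number, and that number lies within the scatter of its nearest neighbour in the series. Compound 3 remains at a limit of the assay and has no number of its own: the limit of > 56.2 uM in this assay, at which 1 of the 4 values shown sits. The change to 3,5-dimethylphenyl in place of 3-fluorophenyl can therefore be read only as an at least 1.2-fold lower number from compound 3 to compound 4 (0.09 log units; that floor lies within the scatter), which shows that this substituted phenyl group gives a measurable result here, but not that the change truly lowers the number or by how much.

The groups shown at this position are all phenyl rings carrying alkyl or fluorine-containing substituents, and their numbers lie close together, so it remains open whether any group here can move the number clearly beyond the scatter. An amine or a carboxylic acid on this phenyl ring, or a plain longer chain in place of the ring, would test that, and the result could go in either direction.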